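The source may hold more compounds than are shown below. What is called first, only, known or untested is meant among the compounds shown, and "the series" means these compounds.

The three measured compounds and their values in a physicochemical assay for solubility, read by LC-MS, in phosphate buffer, measured as kinetic solubility, with a stated time of 4 h, at pH 7.4; on this read-out higher numbers stand for higher solubility and lower numbers for lower solubility:
compound 1 `Cc1ccc(Nc2nc(-c3cc(C(F)(F)F)ccc3F)cs2)cc1` gives 7500 nM;
compound 2 `COc1ccc(-c2csc(Nc3ccc(C)cc3)n2)cc1` gives 1200 nM;
compound 3 `CCOC(=O)c1cc(-c2csc(Nc3ccc(C)cc3)n2)on1` gives 27700 nM.

Compound 3 stands highest of the three numbers in this assay. Its nearest neighbour is compound 1, whose number is lower by a margin beyond the usual scatter, and compound 2 lies further off still, also beyond the scatter. Among the measured compounds shown here, the three compounds differ from one another in more than one place, so no single step between measured compounds can be read from them, and their spread says only that compounds of this shared core can sit well apart in this assay.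

Compound 4 `Cc1ccc(Nc2nc(-c3cc(C(=O)Nc4ccccn4)no3)cs2)cc1` is the next compound, reached from compound 3 by one change: (pyridin-2-yl)amino in place of ethoxy on a carbonyl carbon. For the measured compounds named here, no measured pair shows this change, so the expectation rests on the change alone and on where compound 3 stands. A step downward in this assay is expected, of a size beyond the scatter, though with wide uncertainty. The expected step from compound 3 to compound 4 is a 4.6-fold lower number from compound 3 to compound 4 (0.66 log units; beyond the scatter). Compound 4 is accordingly estimated at 6000 nM, within a range from 1200 nM to 25000 nM.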

Compound 4, solubility: 2400 nM
Compound 4: middle estimate off by 2.5-fold (0.40 log units), on the high side; the range from low to high includes it.
By their numbers in this assay, from the lowest: compounds 2 and 4 (each within the scatter of the next); then compound 1; then compound 3.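

In this assay, among the compounds shown here, (pyridin-2-yl)amino in place of ethoxy on a carbonyl carbon gives a 12-fold lower number from compound 3 to compound 4 (1.06 log units; beyond the scatter), a large step beyond the scatter and the first effect of a single change that can be read in this set, as the earlier compounds differed from one another in more than one place. It shows that the group on this carbonyl carbon is not indifferent in this assay: with the rest of the structure held constant, going from ethoxycarbonyl to (pyridin-2-yl)carbamoyl is enough to move the number well beyond the scatter. No measurement shown here bears on the reason for this step.

The change brings in a six-membered aromatic ring and the amide hydrogen together and also enlarges the group, so the compounds shown leave open which of these differences goes with the step. Still to be seen are the values with phenylamino, which keeps a ring without the ring nitrogen, with methylamino, which keeps the amide hydrogen without a ring, and with the free carboxylic acid on the same carbonyl carbon.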